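A few compounds are considered here, and "the series" means these few. Any claim that something is new, unique, unknown or untested is made for them only; others in the source may bear on it.

Compound 1 `NCCCCNc1cc(/C=C/c2ccccc2)nc2ccccc12`: 6600 nM
Compound 2 `O=C(CN1CCCCC1)NCCNc1cc(/C=C/c2ccccc2)nc2ccccc12`: 4700 nM

In an ADME assay on J774 cells (Mus musculus) for cytotoxicity, read by MTT assay, with a stated time of 48 h (on this read-out higher numbers stand for weaker inhibition and lower numbers for stronger inhibition), compound 1 has only compound 2 as a neighbour, and the two values lie within the scatter of each other. Compound 3 `CC(=O)Nc1cc(/C=C/c2ccccc2)nc2ccccc12` has acetyl in place of 4-aminobutyl on a nitrogen on an aromatic ring. For the measured compounds named here, the one measured step that bears on this, a 1.4-fold lower number from compound 1 to compound 2 (0.15 log units; within the scatter), changed a saturated chain carbon instead and stayed within the scatter, so it offers weak guidance. No shift beyond the scatter is therefore expected in this assay. The expected change is a 1.5-fold higher number from compound 1 to compound 3 (0.18 log units; within the scatter). For compound 3 the estimated value is 10000 nM, with an expected range from 3500 nM to 30000 nM.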

Compound 3, half-maximal inhibitory concentration: > 25000 nM
Compound 3: no number, only a limit; the forecaster's own chance of this, stated with the estimate: 25%; middle value at least 2.5-fold (0.39 log units) away from the limit.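

In this assay, compound 3 gives > 25000 nM, which is a limit and not a number. Acetyl in place of 4-aminobutyl on a nitrogen on an aromatic ring gives an at least 3.7-fold higher number from compound 1 to compound 3 (0.57 log units; beyond the scatter), so a change at this position moves the read-out beyond the scatter, which the earlier change on a saturated chain carbon, a 1.4-fold lower number from compound 1 to compound 2 (0.15 log units; within the scatter), did not. The size of this step rests on a limit: the limit of > 25000 nM in this assay, at which 1 of the 3 values shown sits.

The compounds shown leave open whether the shift follows the loss of the terminal amine, the arrival of the carbonyl, or the change in group size. A plain butyl chain or a 4-aminobutanoyl group on the same nitrogen would separate these.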